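Quinolinone benzylamines: cytotoxicity outlook for hydroxyethyl analogue

The source may hold more compounds than are shown below. What is called first, only, known or untested is meant among the compounds shown, and "the series" means these compounds.

Compound 1 `Cc1ccc2[nH]c(=O)c(CN(Cc3ccc(F)cc3)Cc3ccc(C(C)(C)C)cc3)cc2c1` and compound 2 `Cc1ccc2[nH]c(=O)c(CN(Cc3ccc(C#N)cc3)Cc3ccc(C(C)(C)C)cc3)cc2c1` share one core and differ by cyano in place of fluoro on an aromatic carbon. In a toxicity assay on MDCK cells (Canis lupus familiaris) for cytotoxicity, read by crystal violet staining, with a stated time of 48 h (on this read-out higher numbers stand for lower toxicity in this test and lower numbers for higher toxicity in this test), compound 1 reaches only the limit > 27000 nM. In this assay compound 2 likewise reaches only the limit > 5000 nM, so compound 2 stands at a limit, not at a number. The step that the two limits leave unreadable from compound 1 to compound 2 is therefore not readable; both measured values sit at limits the limit of > 27000 nM in this assay, at which 1 of the 2 values shown sits (the limit of > 5000 nM in this assay, at which 1 of the 2 values shown sits). Compound 3 `Cc1ccc2[nH]c(=O)c(CN(Cc3ccc(C(C)(C)C)cc3)[C@H](CO)c3ccccc3)cc2c1` differs from compound 2 by 2-hydroxy-1-phenylethyl in place of 4-cyanobenzyl on an amine nitrogen. Within the data shown here, no measured step bears on this change. Compound 3 is expected to remain at or near a limit, with an estimated step that the limit leaves unreadable from compound 2 to compound 3, giving an expected value of 25000 nM (range 6000 nM to 100000 nM).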

Compound 3, half-maximal cytotoxic concentration: > 10000 nM
Compound 3 ended at the assay's limit; the forecaster's own chance of this, stated with the estimate: 70%; the middle value does not contradict the limit.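

Compound 3, like compound 1 and compound 2, stands only at a limit in this assay, so no step among these three can be read. The compounds shown leave open where their actual half-maximal cytotoxic concentrations lie and whether either change on the amine nitrogen shifts them.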